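The source may report more compounds than this note shows. Statements on the series, on what has been measured and on what is new or still open speak of the compounds shown alone.

Compound 1 `CC(C)NC(=O)N1CCN(C(=S)SCc2cn(Cc3ccccc3F)nn2)CC1` gives 1620 nM in a functional assay on MGC-803 cells (Homo sapiens) for cytotoxicity, read by MTT assay, with a stated time of 72 h; on this read-out higher numbers stand for weaker inhibition and lower numbers for stronger inhibition.
Compound 2 `Cc1ccc(Cn2cc(CSC(=S)N3CCN(C(=O)NC(C)C)CC3)nn2)cc1` gives 16600 nM in this assay.
Compound 3 `CCN(C)C(=O)N1CCN(C(=S)SCc2cn(Cc3ccc(C)cc3)nn2)CC1` gives 8270 nM in this assay.

Among these three, compound 2 carries the highest number, but its separation from compound 3 is within the scatter, so the two cannot be ordered; only against compound 1 does compound 2 stand apart, as seen in a 10-fold higher number from compound 1 to compound 2 (1.01 log units; beyond the scatter). The change of the urea substituent, a 2.0-fold lower number from compound 2 to compound 3 (0.30 log units; within the scatter), stayed within the scatter.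

Compound 4 `COc1ccc(Cn2cc(CSC(=S)N3CCN(C(=O)NC(C)C)CC3)nn2)cc1` differs from compound 2 by methoxy in place of methyl on an aromatic carbon. Within the data shown here, the one measured step on the same aryl ring, a 10-fold higher number from compound 1 to compound 2 (1.01 log units; beyond the scatter), was large, but it exchanged a 2-fluorophenyl for a 4-methylphenyl and so does not bear directly on a swap of methyl for methoxy at that position. Among the measured compounds shown here, no measured step informs this exact change, so an estimate of compound 4 is uncertain in both directions and is best placed near compound 2 with a wide range. Compound 4 is therefore expected at 13000 nM, between 3500 nM and 45000 nM, a step of a 1.3-fold lower number from compound 2 to compound 4 (0.11 log units; within the scatter) that is expected to remain within the scatter.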

Compound 4, half-maximal inhibitory concentration: 99200 nM
Estimate against measurement, compound 4: 7.6-fold (0.88 log units) below; the whole stated range lies below it.
By their numbers in this assay, from the lowest: compound 1; then compounds 3 and 2 (each within the scatter of the next); then compound 4.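

Methoxy in place of methyl, para to a large group, gives a 6.0-fold higher number from compound 2 to compound 4 (0.78 log units; beyond the scatter) in this assay, so this position on the aryl ring is sensitive to a small change, and here the change goes toward weaker inhibition. Set against the 2-fluorophenyl, the 4-methoxyphenyl gives a 61-fold higher number from compound 1 to compound 4 (1.79 log units; beyond the scatter) and so stands further from it than the 4-methylphenyl does, which gives a 10-fold higher number from compound 1 to compound 2 (1.01 log units; beyond the scatter) on the same comparison. No measurement at hand accounts for this step.

The compounds shown leave open whether a hydroxyl, a chlorine or an amine at this same place would follow methoxy or methyl, and whether a fluorine there would match the 2-fluorophenyl. They also leave open whether the methoxy step holds with the ethyl(methyl)amino group of compound 3.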